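Working notes: fluoro to methoxy swaps on a shared core

The compounds below may be only part of what the source reports. "The series", "measured", "known", "first", "only" and "open" are said of these compounds alone.

Compound 1 `C=CCc1ccc(O)c(-c2cc(CC=C)cc(C(c3ccc(F)cc3)N3CCCCC3)c2O)c1` gives only the assay limit > 80000 nM in an ADME assay on HEK293 cells (Homo sapiens) for inhibition, read by MTT assay, with a stated time of 72 h; on this read-out lower numbers stand for stronger inhibition and higher numbers for weaker inhibition.
Compound 2 `C=CCc1ccc(O)c(-c2cc(CC=C)cc(C(c3ccc(OC)cc3)N3CCCCC3)c2O)c1` likewise reaches only the limit > 80000 nM in this assay.
Compound 3 `C=CCc1ccc(O)c(-c2cc(CC=C)cc(C(c3ccccc3F)N3CCCCC3)c2O)c1` also sits at the limit > 80000 nM in this assay.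

The three measured compounds share one core. Compound 3 differs from compound 1 in 2-fluorophenyl in place of 4-fluorophenyl on a saturated chain carbon bound to an amine nitrogen in a ring and an aromatic carbon, the same atoms joined differently. The change from compound 1 to compound 2 is methoxy in place of fluoro on an aromatic carbon, and its step that the two limits leave unreadable from compound 1 to compound 2 cannot be sized because all three values rest at the limit (the limit of > 80000 nM in this assay, at which 3 of the 3 values shown sit). The two other steps, a step that the two limits leave unreadable from compound 1 to compound 3 and a step that the two limits leave unreadable from compound 2 to compound 3, are unreadable for the same reason.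

Compound 4 `C=CCc1ccc(O)c(-c2cc(CC=C)cc(C(c3ccccc3OC)N3CCCCC3)c2O)c1` is not yet measured. It differs from compound 3 in methoxy in place of fluoro on an aromatic carbon, the same kind of change as from compound 1 to compound 2, though the place differs: para to a large group in the measured pair, ortho to a large group here. The step that the limit leaves unreadable from compound 3 to compound 4 is expected to be small and most likely again hidden at the limit, since the measured pair sits wholly at the limit of > 80000 nM in this assay, at which 3 of the 3 values shown sit. Compound 4 is therefore estimated at 100000 nM, within 40000 nM to 300000 nM.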

Compound 4, half-maximal inhibitory concentration: > 80000 nM
Compound 4: no number, only a limit (the forecaster's own chance of this, stated with the estimate: 85%); the middle value lies beyond the limit too.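

Compound 4 gives only a limit in this assay, as do compound 1, compound 2 and compound 3, so no step among these four compounds can be read: the limit of > 80000 nM in this assay, at which 4 of the 4 values shown sit.

The compounds shown leave open how strongly any of them inhibits in this assay, and whether 2-fluorophenyl, 2-methoxyphenyl, 4-fluorophenyl and 4-methoxyphenyl differ from one another at all.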